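Ester variation on the shared core: paw edema notes

The source may report more compounds than this note shows. Statements on the series, on what has been measured and on what is new or still open speak of the compounds shown alone.

Measured compounds:
compound 1, `CC(C)OC(=O)C(=O)Nc1cccccc1=O`: 76%
compound 2, `CCCCCOC(=O)C(=O)Nc1cccccc1=O`: 61%
compound 3, `O=C(O)C(=O)Nc1cccccc1=O`: 89%; 70% (2 entries)

Within the data shown here, in a functional assay on the whole organism (strain Sprague-Dawley CD) for inhibition, with Rattus norvegicus as the target, read by paw edema, at a dose of 10 mg/kg by the intraperitoneal route (a lower number here means a weaker effect, a higher number a stronger effect of the compound at the dose given), compound 2 gives 61%, the lower of the two single numbers; the one measured step, a number 15 percentage points lower from compound 1 to compound 2 (beyond the scatter), separates it from compound 1, beyond the scatter. Compound 3 has no single number; its entries, (the several entries of compound 3 in this assay, 89%; 70% (2 entries)), spread more than the scatter. Compound 4, `CCOC(=O)COC(=O)C(=O)Nc1cccccc1=O`, differs from compound 2 by ethoxycarbonyl in place of butyl on a saturated chain carbon bound to an oxygen next to a carbonyl group. Among the measured compounds shown here, only the step from compound 1 to compound 2 bears on this change, and it went the modest way of a longer alkyl chain; the entering group, with its two oxygens, has no measured counterpart here, so no shift beyond the scatter is expected, and the estimated step is a number 6 percentage points higher from compound 2 to compound 4 (within the scatter). For compound 4 in this assay the expected value is 67%, within 50% to 84%.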

Compound 4, a percentage reported as inhibition, in the whole organism at one dose (the size of the read-out at that dose, not a potency): 69%
For compound 4 the middle estimate is 2 percentage points below the measured one; the range from low to high includes it.
By their numbers in this assay, from the lowest: compounds 2, 4 and 1 (each within the scatter of the next, the first and the last beyond it).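

In this assay, (ethoxycarbonyl)methyl on an oxygen next to a carbonyl group is tolerated, with neither new step beyond the scatter (a number 8 percentage points higher from compound 2 to compound 4 (within the scatter); a number 7 percentage points lower from compound 1 to compound 4 (within the scatter)). This ester therefore separates from neither pentyl nor isopropyl, even though those two stand apart (a number 15 percentage points lower from compound 1 to compound 2 (beyond the scatter)). At this place, oxygen atoms in the chain go with no measurable loss or gain against either alkyl ester.

As far as these compounds go, whether an amine or a longer chain at this place would leave this range stays open. Single entries also need caution, as repeat entries can spread widely: the several entries of compound 3 in this assay, 89%; 70% (2 entries)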